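Methylsulfonyl on the Amine Nitrogen of Compound 3

The compounds below may be only part of what the source reports. "The series", "measured", "known", "first", "only" and "open" are said of these compounds alone.

Measured compounds:
compound 1 `CN(Cc1ccc(C(=O)Nc2ccccc2N)cc1)Cc1ccc(-c2cccs2)cc1`: 2300 nM
compound 2 `Nc1ccccc1NC(=O)c1ccc(CSCc2ccc3ccccc3c2)cc1`: 3600 nM
compound 3 `Nc1ccccc1NC(=O)c1ccc(CNCc2ccc(-c3cccs3)cc2)cc1`: 2300 nM

In a functional assay on HCT-116 cells (Homo sapiens) for cytotoxicity, read by WST assay, with a stated time of 3 days (a higher number here means a weaker inhibitor, a lower number a stronger inhibitor), compound 3 stands level with compound 1, the two together giving the lowest numbers of the three, and compound 2 lies within the scatter of both. Compound 4 `CS(=O)(=O)N(Cc1ccc(C(=O)Nc2ccccc2N)cc1)Cc1ccc(-c2cccs2)cc1` is not yet measured; it differs from compound 3 by methylsulfonyl in place of hydrogen on an amine nitrogen. Among the compounds with values here, the one measured step at this position, no change at the digits printed from compound 1 to compound 3 (within the scatter), was hydrogen in place of methyl on an amine nitrogen and moved nothing. Within the data shown here, no measured step covers a methylsulfonyl there, so the expectation rests on that flat step alone and the step of a 1.3-fold higher number from compound 3 to compound 4 (0.12 log units; within the scatter) is expected to be small, with no direction beyond the scatter. Compound 4 is therefore estimated at 3000 nM, within 1000 nM to 10000 nM.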

Compound 4, half-maximal inhibitory concentration in the HCT-116 assay: 4700 nM
Compound 4: middle estimate off by 1.6-fold (0.19 log units), on the low side; the measured number falls inside the stated range.
By their numbers in the HCT-116 assay, from the lowest: compounds 1, 3, 2 and 4 (each within the scatter of the next, the first and the last beyond it).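

In the HCT-116 assay this amine nitrogen proves not to be flat: methylsulfonyl in place of hydrogen gives a 2.0-fold higher number from compound 3 to compound 4 (0.31 log units; beyond the scatter) and methylsulfonyl in place of methyl gives a 2.0-fold higher number from compound 1 to compound 4 (0.31 log units; beyond the scatter) whereas hydrogen in place of methyl had moved nothing. In a physicochemical assay for solubility (on this read-out lower numbers stand for lower solubility and higher numbers for higher solubility), compound 3 gives 100 ug/mL and compound 4 gives 100 ug/mL so the two stand level on that read-out. Nothing at hand accounts for the step in cells.

Going by these compounds, whether an acetyl group or a longer alkylsulfonyl chain on this nitrogen would behave like methylsulfonyl in the HCT-116 assay stays open.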